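Adding a Chloro Group to Compound 2

The compounds below may be only part of what the source reports. "The series", "measured", "known", "first", "only" and "open" are said of these compounds alone.

Compound 1: `N=C(NO)NS(=O)(=O)c1cc(-c2nnc(-c3ccc(Cl)cc3)s2)c(Cl)cc1SCc1ccccc1` — 1670 nM
Compound 2: `COc1cc(CSc2cc(Cl)c(-c3nc(-c4ccccc4)no3)cc2S(=O)(=O)NC(=N)NO)cc(OC)c1OC` — 7240 nM
Compound 3: `N=C(NO)NS(=O)(=O)c1cc(-c2nc(-c3ccccc3)no2)c(Cl)cc1SCc1ccccc1` — 1900 nM

In a functional assay on HT-29 cells (Homo sapiens) (on this read-out higher numbers stand for weaker inhibition of growth and lower numbers for stronger inhibition of growth), compound 2 gives 7240 nM, the highest of the three numbers. Its nearest neighbour is compound 3, with a 3.8-fold lower number from compound 2 to compound 3 (0.58 log units; beyond the scatter); compound 1 lies furthest from it. That step replaced a 3,4,5-trimethoxyphenyl by a phenyl on the saturated chain carbon bound to a sulfur, a different part of the molecule from the change considered here.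

Compound 4, `COc1cc(CSc2cc(Cl)c(-c3nc(-c4ccc(Cl)cc4)no3)cc2S(=O)(=O)NC(=N)NO)cc(OC)c1OC`, differs from compound 2 by chloro in place of hydrogen on an aromatic carbon: one chlorine enters on an aromatic carbon of the six-membered carbon ring, para to a large group, so that the phenyl becomes a 4-chlorophenyl.

Among the measured compounds shown here, no measured step isolates this change. For the measured compounds named here, compound 1 carries a 4-chlorophenyl and compound 3 a phenyl, but they also differ in the five-membered ring joining that phenyl to the core, so no single step links them. Compound 1 gives 1670 nM and compound 3 gives 1900 nM, two numbers within the usual scatter of each other. On that basis the chloro group is expected to move the number little, if at all: compound 4 is estimated at 6500 nM (range 2500 nM to 16000 nM), a step of a 1.1-fold lower number from compound 2 to compound 4 (0.05 log units; within the scatter) that is expected to stay within the scatter.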

Compound 4, concentration for 50% growth inhibition: 2950 nM
Beside the measured number, compound 4's estimate is 2.2-fold (0.34 log units) above it; the range from low to high includes it.
By their numbers in this assay, from the lowest: compounds 1, 3 and 4 (each within the scatter of the next); then compound 2.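

The phenyl of compound 2 turns out to be a position that responds in this assay: making it a 4-chlorophenyl gives a 2.5-fold lower number from compound 2 to compound 4 (0.39 log units; beyond the scatter), which means stronger inhibition of growth. Among the compounds shown here, this is the first direct reading at this position, and it shows that a single chlorine, an addition of one heavy atom with no hydrogen-bond donors or acceptors, is enough to produce a modest step beyond the scatter. Compound 2 now has two single changes that each lower its number, this one and the change at the other end of the molecule, a 3.8-fold lower number from compound 2 to compound 3 (0.58 log units; beyond the scatter); nothing available explains why the chloro group has this effect.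

Whether the chloro group would lower the number as well in a compound with a phenyl in place of the 3,4,5-trimethoxyphenyl remains open, as no pair among these compounds tests the change with that group present. Also unknown is how a fluoro, a bromo or an amine on the same aromatic carbon would compare with the chloro group, so this one step cannot yet show what this position favours.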